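The source may hold more compounds than are shown below. What is called first, only, known or untested is meant among the compounds shown, and "the series" means these compounds.

In an ADME assay on Caco-2 cells (Homo sapiens) for permeability, read by LC-MS, in the apical to basolateral direction, with a stated time of 60 min, at pH 6.5 (a higher number here means that the compound crosses the layer faster, a lower number that the compound crosses the layer more slowly), compound 1 `CC(C)(C)[C@@H](O)C(=O)N1[C@@H]2C[C@@H]2C[C@H]1C(=O)NCc1cc(Cl)ccc1-n1cnnn1` gives 34 10^-6 cm/s and stands highest among the three compounds measured. Compound 2 `CC(C)(C)[C@@H](O)C(=O)N1Cc2ccccc2[C@H]1C(=O)NCc1cc(Cl)ccc1-n1nnnn1` gives 9 10^-6 cm/s in this assay, a gap from compound 1 that lies beyond the scatter, and compound 3 `O=C(NCc1cc(Cl)ccc1-n1cnnn1)[C@@H]1[C@H]2C[C@H]2CN1C(=O)[C@H](O)Cn1cccn1` gives 0.31 10^-6 cm/s in this assay, the furthest from compound 1. Compound 4 `O=C(NCc1cc(Cl)ccc1-n1cnnn1)[C@@H]1C[C@H]2C[C@H]2N1C(=O)[C@H](O)CC1CC1` has not yet been measured. It differs from compound 1 in one place: cyclopropylmethyl in place of tert-butyl on a saturated chain carbon bound to a carbonyl carbon and an oxygen on a saturated carbon. The group that leaves and the group that enters carry the same count of heavy atoms, no hydrogen-bond donors or acceptors, and no charge, so the change is small in what is counted. Within the data shown here, no step between two measured compounds shows the effect of such a change directly. The step from compound 1 to compound 4 in this assay is expected to stay within the usual scatter, as a 1.4-fold lower number from compound 1 to compound 4 (0.13 log units; within the scatter). For compound 4 in this assay the estimate is 25 10^-6 cm/s, with a range from 12 10^-6 cm/s to 50 10^-6 cm/s.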

Compound 4, apparent permeability: 6.9 10^-6 cm/s
Beside the measured number, compound 4's estimate is 3.6-fold (0.56 log units) above it; measured number outside the range, below it.
By their numbers in this assay, from the lowest: compound 3; then compounds 4 and 2 (each within the scatter of the next); then compound 1.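

With the step from tert-butyl to cyclopropylmethyl, the compounds give their first direct reading of a change at this place, on a saturated chain carbon bound to a carbonyl carbon and an oxygen on a saturated carbon. In this assay, the data show a 4.9-fold lower number from compound 1 to compound 4 (0.69 log units; beyond the scatter), which lies beyond the scatter even though the two groups match in heavy atoms, hydrogen-bond donors and acceptors, and charge. Matching counts therefore did not keep the numbers together in this pair, and nothing at hand accounts for the difference.

The compounds shown leave open how a straight butyl chain, an amine or a carboxylic acid at this place would read in this assay. They also leave open whether the same exchange would give a step of this size on the core of compound 2.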